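Fluoro in place of hydrogen on compound 2

A few compounds are considered here, and "the series" means these few. Any claim that something is new, unique, unknown or untested is made for them only; others in the source may bear on it.

Measured so far in a functional assay on PC-3 cells (Homo sapiens) for cytotoxicity, with a stated time of 48 h; a lower number here means a stronger inhibitor, a higher number a weaker inhibitor:
compound 1 `COc1cc(OC)c(C(=O)/C=C/c2ccccc2SC)c(OC)c1` gives 7600 nM
compound 2 `COc1cc(OC)c(C(=O)/C=C/c2ccccc2)c(OC)c1` gives 5100 nM

Compound 2 lies within the scatter of compound 1, so these two numbers do not separate them. Compound 3 `COc1cc(OC)c(C(=O)/C=C/c2ccc(F)cc2)c(OC)c1` is still unmeasured. Its difference from compound 2 is fluoro in place of hydrogen on an aromatic carbon and turns phenyl into 4-fluorophenyl, para to a large group. Going by the values given here, one measured step bears on this, and only loosely: a 1.5-fold lower number from compound 1 to compound 2 (0.17 log units; within the scatter) for hydrogen in place of methylsulfanyl on an aromatic carbon. Among the compounds with values here, that step involves another group, and no measured step covers fluoro. No shift beyond the scatter is therefore expected in this assay and no direction is favoured, so the estimate starts from compound 2 (5100 nM). The expected change is a 1.0-fold lower number from compound 2 to compound 3 (0.01 log units; within the scatter) and remains tentative. For compound 3 the estimated value is 5000 nM (expected range 2300 nM to 11000 nM).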

Compound 3, half-maximal inhibitory concentration: 5500 nM
Compound 3: the middle estimate sits 1.1-fold (0.04 log units) below what was measured; the range from low to high includes it.
By their numbers in this assay, from the lowest: compounds 2, 3 and 1 (each within the scatter of the next).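

In this assay, the change from phenyl to 4-fluorophenyl, para to a large group, comes with a 1.1-fold higher number from compound 2 to compound 3 (0.03 log units; within the scatter), so a single fluoro at this position is not separated from hydrogen. The other comparison, 4-fluorophenyl in place of 2-(methylsulfanyl)phenyl, comes with a 1.4-fold lower number from compound 1 to compound 3 (0.14 log units; within the scatter), so these two substituted rings are not separated either, and none of the three compounds stands apart from the others. Nothing measured on these compounds bears on the reason for this result.

Going by these compounds, it remains open whether a larger or charged group at this position, such as an amine, a carboxylic acid or a longer alkoxy chain, would move the number beyond the scatter. Also open, on these data alone, is whether any change to the shared core would do so.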